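This account rests on a few compounds, and the source may have more. Where it says the series, first, only, none or still open, it means among the compounds named here.

Measured compounds in an assay on CHO cells with Alpha-2C adrenergic receptor (Homo sapiens) as the target; a higher number here means a larger maximal response, a lower number a smaller maximal response:
compound 1 `C=C(C)c1ccccc1OC(C)C1=NCCN1` gives 0.71
compound 2 `C=COc1ccccc1OC(C)C1=NCCN1` gives 0.48

Compound 2 stands lowest of the two numbers; its nearest neighbour is compound 1, separated by the step a number 0.23 lower from compound 1 to compound 2 (beyond the scatter), which lies beyond the scatter. Compound 3 `CCc1ccccc1OC(C)C1=NCCN1` differs from compound 2 as follows: ethyl in place of vinyloxy on an aromatic carbon. For the measured compounds named here, the only measured step that bears on this is the one from compound 1 to compound 2, where a carbon-only group was replaced by vinyloxy and the number fell; the present change removes vinyloxy again for a carbon-only group, so a modest rise is expected, a number 0.14 higher from compound 2 to compound 3 (beyond the scatter). For compound 3 the expected value is 0.62, between 0.45 and 0.8.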

Compound 3, intrinsic activity: the largest response reached, as a fraction of the reference agonist's: 0.6
Estimate against measurement, compound 3: 0.020 above; measured number inside the range.
By their numbers in this assay, from the lowest: compound 2; then compound 3; then compound 1.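

In this assay, ethyl on this aromatic carbon sits apart from both other groups: a number 0.12 higher from compound 2 to compound 3 (beyond the scatter) against vinyloxy, and a number 0.11 lower from compound 1 to compound 3 (beyond the scatter) against 1-methylethenyl. Both carbon-only groups thus stand above vinyloxy in these three compounds, yet they also differ from each other, so lacking the oxygen does not by itself fix the number. Nothing available accounts for either step. Open, from the compounds shown here alone, is whether methoxy or a longer chain such as propyl at this aromatic carbon would follow the same order.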